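Replacing the hydroxyphenyl group with a fused bicyclic amine

A few compounds are considered here, and "the series" means these few. Any claim that something is new, unique, unknown or untested is made for them only; others in the source may bear on it.

Measured compounds:
- compound 1, `CCC(C)(C)Cc1c[nH]c(CCc2ccc(-c3ccccc3O)cc2)n1`: 31 nM
- compound 2, `CCC(C)(C)Cc1c[nH]c(CCc2ccc(-c3ccccc3OCc3nc(C(F)(F)F)n[nH]3)cc2)n1`: 127 nM

Going by the values given here, in an assay on isolated protein for binding affinity to Bombesin receptor subtype-3 (Homo sapiens) (on this read-out higher numbers stand for weaker inhibition and lower numbers for stronger inhibition), compound 1 gives 31 nM, the lowest of the two numbers known. Compound 2 gives 127 nM in this assay. Among the compounds with values here, the one step between them, a 4.1-fold higher number from compound 1 to compound 2 (0.61 log units; beyond the scatter), shows that building out from the oxygen of the hydroxyphenyl group costs affinity by a modest amount.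

Compound 3 `CCC(C)(C)Cc1c[nH]c(CCc2ccc(N3CCCc4cn[nH]c43)cc2)n1` has not yet been measured. It differs from compound 1 by a group of 9 heavy atoms (6 carbon, 3 nitrogen; one five-membered aromatic ring with 2 hetero atoms, one six-membered non-aromatic ring with 1 hetero atom) in place of a group of 7 heavy atoms (6 carbon, 1 oxygen; one six-membered aromatic ring of carbon only), on an aromatic carbon. Within the data shown here, no measured step removes the hydroxyphenyl group entirely, so there is no direct precedent. Among the measured compounds shown here, the only step available, from compound 1 to compound 2, touched this same end of the molecule and gave a modest loss; a full exchange of the group is a larger structural change, so a loss of similar or somewhat greater size is the most reasonable expectation, with wide uncertainty in both directions.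

Compound 3 is therefore estimated to give 90 nM in this assay, with a range from 15 nM to 500 nM. This estimate corresponds to an expected step of a 2.9-fold higher number from compound 1 to compound 3 (0.46 log units; beyond the scatter).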

Compound 3, half-maximal inhibitory concentration: 18 nM
Compound 3: the middle estimate sits 5.0-fold (0.70 log units) above what was measured; measured number inside the range.
By their numbers in this assay, from the lowest: compounds 3 and 1 (each within the scatter of the next); then compound 2.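

In this assay the full exchange of the 2-hydroxyphenyl group, on an aromatic carbon para to a large group, gives a 1.7-fold lower number from compound 1 to compound 3 (0.24 log units; within the scatter) and leaves the two compounds level. The earlier step only built out from the oxygen, whereas this one shows that the whole 2-hydroxyphenyl group can go without a loss beyond the scatter: a group with no oxygen and no six-membered aromatic ring of carbon only, holding instead a five-membered aromatic ring with 2 hetero atoms and a six-membered non-aromatic ring with 1 hetero atom, does as well at this position. Nothing available here accounts for the two different groups giving such similar numbers.

The compounds shown do not say which parts of the new group matter, as a lone pyrazole ring or a lone piperidine ring at the same place would be needed to separate the contributions of its two rings. Likewise, a plain phenyl ring without the hydroxyl group would be needed to tell whether the oxygen of compound 1 contributes anything at all.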